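Compound 2 and the step to a bromo group

The source may report more compounds than this note shows. Statements on the series, on what has been measured and on what is new or still open speak of the compounds shown alone.

Among the compounds with values here, in an ADME assay on BHK cells (Mesocricetus auratus) for cytotoxicity, read by MTT assay, with a stated time of 96 h (a lower number here means that less compound is tolerated, a higher number that more compound is tolerated), compound 2 `FC(F)(F)c1cccc(NC(=S)Nc2ccccc2)c1` gives 41000 nM and holds the higher of the two numbers measured so far. In this assay compound 1 `FC(F)(F)c1cccc(NC(=S)Nc2ccc(I)cc2)c1` gives 9400 nM and stands below it. Compound 3 `FC(F)(F)c1cccc(NC(=S)Nc2cccc(Br)c2)c1` has bromo in place of hydrogen on an aromatic carbon, meta to a large group bromo in place of hydrogen on an aromatic carbon and is otherwise the same as compound 2. Within the data shown here, only one measured step bears on this change: a 4.4-fold higher number from compound 1 to compound 2 (0.64 log units; beyond the scatter) where hydrogen replaces iodo. Read in reverse, this modest step beyond the scatter points to a lower number when a halogen enters. Bromo is not iodo, however, and one step is thin evidence, so a somewhat smaller move is expected. The expected change is a 2.6-fold lower number from compound 2 to compound 3 (0.41 log units; beyond the scatter) towards less compound tolerated. Compound 3 is estimated at 16000 nM and expected to fall between 6500 nM and 38000 nM.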

Compound 3, half-maximal cytotoxic concentration: 10000 nM
Beside the measured number, compound 3's estimate is 1.6-fold (0.20 log units) above it; measured number inside the range.
By their numbers in this assay, from the lowest: compounds 1 and 3 (each within the scatter of the next); then compound 2.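

In this assay, the change to 3-bromophenyl gives a 4.1-fold lower number from compound 2 to compound 3 (0.61 log units; beyond the scatter), so the drop from the unsubstituted phenyl no longer rests on the iodo compound alone. The two halogenated compounds do not separate, with a 1.1-fold higher number from compound 1 to compound 3 (0.03 log units; within the scatter): although the halogen and its place both differ, 3-bromophenyl and 4-iodophenyl cannot be told apart in this read-out. No measurement shown here accounts for the lower numbers of compound 1 and compound 3.

Bromo and iodo each appear at only one place, so the compounds shown leave the effect of the halogen unseparated from that of its place on the ring. They also leave open whether a non-halogen group, such as an amine or a methoxy group, would move the number in the same way.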